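Phenyl in place of thiophen-2-yl: expected step

A few compounds are considered here, and "the series" means these few. Any claim that something is new, unique, unknown or untested is made for them only; others in the source may bear on it.

Compound 1 `Cn1cccc1-c1cc(-c2cccs2)nc(N)c1C#N` is the reference of this set. In a functional assay on OVCAR-4 cells (Homo sapiens) for inhibition, read by sulforhodamine B assay, with a stated time of 48 h (on this read-out lower numbers stand for stronger inhibition of growth and higher numbers for weaker inhibition of growth), compound 1 gives 85100 nM. Compound 2 `Cn1cccc1-c1cc(-c2cccs2)[nH]c(=O)c1C#N` and compound 3 `Cn1cccc1-c1cc(-c2ccccc2)[nH]c(=O)c1C#N` carry another core; how the core of compound 1 and the core of compound 2 differ is not broken down here. In this assay compound 2 reaches only a limit of the assay, > 100000 nM. Compound 3 likewise reaches only a limit, > 100000 nM. The step that the two limits leave unreadable from compound 2 to compound 3 is therefore not readable, as both values sit at the limit of > 100000 nM in this assay, at which 2 of the 3 values shown sit. The change in that pair is phenyl in place of thiophen-2-yl on an aromatic carbon. Compound 4 `Cn1cccc1-c1cc(-c2ccccc2)nc(N)c1C#N` is not yet measured and differs from compound 1 by phenyl in place of thiophen-2-yl on an aromatic carbon. The two places differ only in that the one is meta to a group of 1 heavy atom and the other meta to an amino group (1 heavy atom), so the change is of the same kind, not the same. The measured pair gives no size for it. The step from compound 1 to compound 4 in this assay is expected to be small, a 1.1-fold higher number from compound 1 to compound 4 (0.02 log units; within the scatter), resting on compound 1 at 85100 nM and on the unreadable step of the other pair. Compound 4 is estimated at 90000 nM, between 30000 nM and 250000 nM, with a fair chance that only a limit is reported.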

Compound 4, concentration for 50% growth inhibition: 46800 nM
Estimate against measurement, compound 4: 1.9-fold (0.28 log units) above, and the stated range covers the measured number.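

On the core of compound 1, phenyl in place of thiophen-2-yl gives a 1.8-fold lower number from compound 1 to compound 4 (0.26 log units; within the scatter) in this assay, so compound 1 and compound 4 cannot be told apart on this read-out. On the other core, the same change between compound 2 and compound 3 cannot be read, because both compounds reach only a limit of the assay: the limit of > 100000 nM in this assay, at which 2 of the 4 values shown sit.

The series therefore shows that the change is tolerated on the core of compound 1, but it gives no size on the other core against which to test whether the change carries over, and so it offers neither agreement nor conflict between the two cores.

Still open, as far as these compounds go, is whether a group of another kind in the place of thiophen-2-yl, such as a carboxylic acid or a morpholine, would move the number beyond the scatter on the core of compound 1. Also open, from the compounds shown here alone, is whether a longer chain on the amino group of compound 1 would do so.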